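Methylating the amide nitrogen of a pituitary-active peptide

This account rests on a few compounds, and the source may have more. Where it says the series, first, only, none or still open, it means among the compounds named here.

Compound 1 `CC(C)(N)CC(=O)N[C@H](CCc1ccccc1)C(=O)NCc1ccc(-c2ccccc2-c2nn[nH]n2)cc1`: 0.2 uM
Compound 2 `CC(C)N(Cc1ccc(-c2ccccc2-c2nn[nH]n2)cc1)C(=O)[C@@H](CCc1ccccc1)NC(=O)C(C)(C)N`: > 0.5 uM

For the measured compounds named here, in a functional assay (Pituitary gland cell) with Rattus norvegicus as the target (a lower number here means that less compound is needed, a higher number that more compound is needed for the effect), compound 1 gives 0.2 uM, the only real number among the two values shown. Compound 2 gives > 0.5 uM, which is a limit of the assay rather than a number (the limit of > 0.5 uM in this assay, at which 1 of the 2 values shown sits). Compound 3 `CN(Cc1ccc(-c2ccccc2-c2nn[nH]n2)cc1)C(=O)[C@@H](CCc1ccccc1)NC(=O)CC(C)(C)N` differs from compound 1 by methyl in place of hydrogen on an amide-type nitrogen. Going by the values given here, no measured pair shares exactly this change, so the size of the step is open. A modest weakening is expected, and compound 3 is estimated at 0.4 uM (range 0.1 uM to 1.5 uM), a step of a 2.0-fold higher number from compound 1 to compound 3 (0.30 log units; within the scatter) in this assay that may still fall within the usual scatter.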

Compound 3, concentration for half-maximal effect: > 0.3 uM
Compound 3: a limit, no number (the forecaster's own chance of this, stated with the estimate: 30%); the middle value is on the limit's open side.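

Placing methyl on this amide-type nitrogen gave compound 3 no number, only a limit: the limit of > 0.3 uM in this assay, at which 1 of the 3 values shown sits.

The change therefore corresponds to an at least 1.5-fold higher number from compound 1 to compound 3 (0.17 log units; that floor lies within the scatter). For the compounds shown here, this is the first reading of this single change, and it sets only a floor, so neither a real loss nor its absence can be claimed.

Going by these compounds, the true size of the step remains open, since a limit has no upper end. Also open, on these data alone, is whether an ethyl group on this nitrogen would give a measurable value.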